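The compounds below may be only part of what the source reports. "The series", "measured", "known", "first", "only" and "open" are said of these compounds alone.

Values in a functional assay on MCF7 cells (Homo sapiens) for antiproliferative activity; on this read-out higher numbers stand for weaker inhibition and lower numbers for stronger inhibition:

- compound 1 `CC(C)=CCc1cc(C(=O)Nc2cc3ccc(OCC4CCN(C)C4)c(C)c3oc2=O)ccc1O`: 1550 nM
- compound 2 `CC(C)=CCc1cc(C(=O)Nc2cc3ccc(OCCCN(C(C)C)C(C)C)c(C)c3oc2=O)ccc1O`: 1310 nM
- compound 3 `CC(C)=CCc1cc(C(=O)Nc2cc3ccc(OCCCNCC(=O)O)c(C)c3oc2=O)ccc1O`: 18100 nM

Compound 3 has the highest number of the three and is the weakest inhibitor here. This is shown by a 12-fold higher number from compound 1 to compound 3 (1.07 log units; beyond the scatter) and by a 14-fold higher number from compound 2 to compound 3 (1.14 log units; beyond the scatter), both large steps. Compound 4 `CC(C)=CCc1cc(C(=O)Nc2cc3ccc(OCCCNCC(N)=O)c(C)c3oc2=O)ccc1O` keeps everything in compound 3 except for one change, amino in place of hydroxy on a carbonyl carbon.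

Within the data shown here, no measured compound carries the carbamoylmethyl group, so no step measures this change directly. The nearest evidence is indirect. Among the measured compounds shown here, compound 1 and compound 2 have quite different amine groups, yet a 1.2-fold lower number from compound 1 to compound 2 (0.07 log units; within the scatter) stays within the scatter, while only compound 3, the one compound with a carboxy group, stands apart. The data cannot separate the carboxy group from the rest of the (carboxymethyl)amino group. Some, but probably not all, of the large gap is therefore expected to close, and the expected change is a 4.0-fold lower number from compound 3 to compound 4 (0.60 log units; beyond the scatter), toward a lower number. For compound 4 the estimated value is 4500 nM, with an expected range of 1500 nM to 13000 nM.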

Compound 4, half-maximal inhibitory concentration: 1460 nM
Compound 4: the middle estimate sits 3.1-fold (0.49 log units) above what was measured; the whole stated range lies above it.
By their numbers in this assay, from the lowest: compounds 2, 4 and 1 (each within the scatter of the next); then compound 3.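

In this assay, among these compounds, amino in place of hydroxy on the carbonyl carbon gives a 12-fold lower number from compound 3 to compound 4 (1.09 log units; beyond the scatter), so the large gap that set compound 3 apart closes while the rest of the (carboxymethyl)amino group stays in place, a separation the earlier compounds could not make. The steps of a 1.1-fold higher number from compound 2 to compound 4 (0.05 log units; within the scatter) and a 1.1-fold lower number from compound 1 to compound 4 (0.03 log units; within the scatter) both lie within the scatter, so among these four compounds only compound 3, the one with a carboxy group, stands apart, and carbamoyl on this chain reads the same as the quite different amine groups of the other two. Nothing measured here bears on why this single exchange has so large an effect.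

The compounds shown leave open whether other groups on this carbonyl carbon, such as a methyl ester or a dimethylamide, would fall with compound 3 or with compound 4. They also leave open whether a longer chain carrying the carbamoyl group, or a carboxylic acid on a longer chain, would follow the same pattern.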